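This account rests on a few compounds, and the source may have more. Where it says the series, first, only, none or still open, it means among the compounds named here.

Measured compounds in an ADME assay on THP-1 cells (Homo sapiens) for cytotoxicity; on this read-out lower numbers stand for stronger inhibition and higher numbers for weaker inhibition:
- compound 1 `COc1ccc(/C=N/NC(=O)c2ccc(-c3nnc(-c4ccccc4OC)o3)cc2)cc1O`: 260000 nM
- compound 2 `COc1ccccc1-c1nnc(-c2ccc(C(=O)N/N=C/c3ccc(O)cc3)cc2)o1`: 261000 nM
- compound 3 `COc1ccccc1-c1nnc(-c2ccc(C(=O)N/N=C/c3ccc(Cl)cc3Cl)cc2)o1`: 78800 nM

Compound 3 gives the lowest number of the three: a 3.3-fold lower number from compound 1 to compound 3 (0.52 log units; beyond the scatter) and a 3.3-fold lower number from compound 2 to compound 3 (0.52 log units; beyond the scatter), both beyond the scatter, whereas compound 1 and compound 2 lie within the scatter of each other (a 1.0-fold higher number from compound 1 to compound 2 (0.00 log units; within the scatter)).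

The next compound, compound 4 `COc1ccccc1-c1nnc(-c2ccc(C(=O)N/N=C/c3ccc(O)cc3O)cc2)o1`, differs from compound 3 in one place: 2,4-dihydroxyphenyl in place of 2,4-dichlorophenyl on a carbon with a double bond to nitrogen. Both measured steps bear on this change, since each replaced a hydroxyl-bearing phenyl on the same carbon with the 2,4-dichlorophenyl and lowered the number by a modest amount. Compound 4 reverses that direction, putting a hydroxyl-bearing phenyl back in place of the 2,4-dichlorophenyl. Going by the values given here, a modest rise in this assay is therefore expected, of a size near the earlier steps, which is the expectation carried by a 2.9-fold higher number from compound 3 to compound 4 (0.47 log units; beyond the scatter). Compound 4 is estimated at 230000 nM, with a range from 120000 nM to 450000 nM.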

Compound 4, half-maximal inhibitory concentration: 104000 nM
The estimate for compound 4 lay 2.2-fold (0.34 log units) above the measured number, outside the stated range (below it).
By their numbers in this assay, from the lowest: compounds 3 and 4 (each within the scatter of the next); then compounds 1 and 2 (each within the scatter of the next).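

In this assay, the lower number is not confined to the 2,4-dichlorophenyl on this carbon: a 1.3-fold higher number from compound 3 to compound 4 (0.12 log units; within the scatter), so exchanging both chlorine atoms for hydroxy groups leaves the read-out within the scatter. Hydroxy groups as such therefore do not decide the number, since adding one hydroxy on an aromatic carbon gives a 2.5-fold lower number from compound 2 to compound 4 (0.40 log units; beyond the scatter), and the change from the 3-hydroxy-4-methoxyphenyl gives a 2.5-fold lower number from compound 1 to compound 4 (0.40 log units; beyond the scatter), though compound 1 and compound 2 also carry hydroxyl-bearing phenyls and remain higher. No available data explain why these hydroxyl-bearing phenyls differ.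

On these data alone, whether an amine or a carboxylic acid in place of the hydroxy groups of compound 4 would keep the number at this level remains open. So does whether a phenyl bearing only one chlorine would match compound 3.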